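Cytotoxicity on MDBK cells: amide side-chain amine swap

The source may hold more compounds than are shown below. What is called first, only, known or untested is meant among the compounds shown, and "the series" means these compounds.

Measured so far:
Compound 1 `CCN(CC)CC(=O)Nc1ccc(-c2nc3cc(C(F)(F)F)ccc3n2C)cc1` gives 57000 nM
Compound 2 `CC(=O)Nc1ccc(-c2nc3cc(C(F)(F)F)ccc3n2C)cc1` gives 46000 nM
Compound 3 `Cn1c(-c2ccc(NC(=O)CN3CCN(c4ccccc4)CC3)cc2)nc2cc(C(F)(F)F)ccc21` gives 1400 nM

The three compounds share one core and differ only in the group on the saturated chain carbon bound to the carbonyl carbon. In an ADME assay on MDBK cells (Bos taurus) for cytotoxicity, read by MTT assay, with a stated time of 96 h (on this read-out higher numbers stand for lower toxicity in this test and lower numbers for higher toxicity in this test), compound 3 stands lowest of the three numbers, which means the highest toxicity in this set; the two other compounds sit within the scatter of each other, as shown by a 1.2-fold lower number from compound 1 to compound 2 (0.09 log units; within the scatter).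

Compound 4 `Cn1c(-c2ccc(NC(=O)CN3CCCC3)cc2)nc2cc(C(F)(F)F)ccc21` carries the change (pyrrolidin-1-yl in place of 4-phenylpiperazin-1-yl on a saturated chain carbon bound to a carbonyl carbon). Going by the values given here, the steps that bear on this are a 41-fold lower number from compound 1 to compound 3 (1.61 log units; beyond the scatter) and a 33-fold lower number from compound 2 to compound 3 (1.52 log units; beyond the scatter), both large and in the same direction: the 4-phenylpiperazin-1-yl group is the one feature that sets compound 3 apart. Removing it and putting in a pyrrolidin-1-yl, a group closer in size to the diethylamino of compound 1, is expected to undo much of that drop, so a large step upward in this assay is expected, a 29-fold higher number from compound 3 to compound 4 (1.46 log units; beyond the scatter). Compound 4 is therefore estimated at 40000 nM, with a range from 15000 nM to 90000 nM.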

Compound 4, half-maximal cytotoxic concentration: 65000 nM
Compound 4: the middle estimate sits 1.6-fold (0.21 log units) below what was measured; the range from low to high includes it.
By their numbers in this assay, from the lowest: compound 3; then compounds 2, 1 and 4 (each within the scatter of the next).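

In this assay, the step of a 46-fold higher number from compound 3 to compound 4 (1.67 log units; beyond the scatter) shows that the low number of compound 3 is not kept once pyrrolidin-1-yl replaces 4-phenylpiperazin-1-yl. Against the two other compounds, the readings are a 1.4-fold higher number from compound 2 to compound 4 (0.15 log units; within the scatter) and a 1.1-fold higher number from compound 1 to compound 4 (0.06 log units; within the scatter), so hydrogen, diethylamino and pyrrolidin-1-yl cannot be told apart at this position, and a non-aromatic ring on this saturated chain carbon is not enough by itself to give the low number of compound 3. No measurement at hand accounts for the large step.

From the compounds shown here alone, it remains open which part of 4-phenylpiperazin-1-yl goes with the low number: a piperazine without the phenyl ring, or a 4-phenylpiperidine, would separate the two. Also open, going by these compounds, is whether the picture holds with a longer chain bound to the carbonyl carbon.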